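From a Trifluoromethyl Ring to a Carboxy Ring

The source may hold more compounds than are shown below. What is called first, only, known or untested is meant among the compounds shown, and "the series" means these compounds.

Compound 1 `O=C1c2ccc(OCc3cccc(-c4ccc(C(F)(F)F)cc4F)c3)cc2CN1C1CCCC1` is the starting point, but it gives no number to build on: in an ADME assay on microsomes from liver (Rattus norvegicus) for metabolic stability, read by LC-MS, with a stated time of 1 h, at 37 degrees C, tested at 4 uM (on this read-out lower numbers stand for a less stable compound and higher numbers for a more stable compound), compound 1 is recorded as "not determined" (no result reported) with no result reported. The structural change is small to describe (4-carboxy-2-chlorophenyl in place of 2-fluoro-4-(trifluoromethyl)phenyl on an aromatic carbon): 4-carboxy-2-chlorophenyl replaces 2-fluoro-4-(trifluoromethyl)phenyl on an aromatic carbon, meta to a large group. The product is compound 3 `O=C(O)c1ccc(-c2cccc(COc3ccc4c(c3)CN(C3CCCC3)C4=O)c2)c(Cl)c1` and it has yet to be tested. Among the measured compounds shown here, the only guide is compound 2 `O=C(O)c1cc(-c2cccc(COc3ccc4c(=O)n(C5CCCC5)sc4c3)c2)ccc1F` which also carries a carboxy group, though on a different core. In this assay compound 2 shows 71% so a clear upward step is expected, towards more compound remaining, although its size cannot be checked without a number for compound 1. For compound 3 the estimated value is 65% (expected range 40% to 88%).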

Compound 3, percent of the compound remaining: 3%
Compound 3: the middle estimate sits 62 percentage points above what was measured; the measured number lies below the stated range.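

In this assay, among the compounds shown here, compound 3 gives 3% and compound 1 gives "not determined" (no result reported) so no step between compound 1 and compound 3 can be read. What swapping the ring does to stability stays open, and no evidence shown bears on this result.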